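The source may report more compounds than this note shows. Statements on the series, on what has been measured and on what is new or still open speak of the compounds shown alone.

In a functional assay on A549 cells (Homo sapiens) for cytotoxicity, with a stated time of 48 h (on this read-out lower numbers stand for stronger inhibition and higher numbers for weaker inhibition), compound 3 `C[S+]([O-])/C=C/c1cc(=O)c2cc(F)ccc2o1` gives 2100 nM. Of the three numbers measured, its number is the second highest, nearest to compound 2 `C[S+]([O-])/C=C/c1cc(=O)c2ccccc2o1`, which gives 1900 nM, and furthest from compound 1 `CC(C)C(=O)Oc1ccc2oc(/C=C/[S+](C)[O-])cc(=O)c2c1`, which gives 2400 nM, yet all three lie within the usual scatter of one another. Compound 4 `CCCC(=O)Oc1ccc2oc(/C=C/[S+](C)[O-])cc(=O)c2c1` differs from compound 3 by (propylcarbonyl)oxy in place of fluoro on an aromatic carbon. The measured step closest to this change is the reverse of a 1.1-fold lower number from compound 1 to compound 3 (0.06 log units; within the scatter), and a 1.1-fold higher number from compound 2 to compound 3 (0.04 log units; within the scatter) touches the same position. Neither step moved this assay beyond the scatter, so the expected step of a 1.1-fold higher number from compound 3 to compound 4 (0.04 log units; within the scatter) is none beyond the scatter. Compound 4 is therefore estimated at 2300 nM, with a range from 1200 nM to 4600 nM.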

Compound 4, half-maximal inhibitory concentration: 2200 nM
Compound 4: the middle estimate sits 1.0-fold (0.02 log units) above what was measured, and the stated range covers the measured number.
By their numbers in this assay, from the lowest: compounds 2, 3, 4 and 1 (each within the scatter of the next).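

In this assay, the first ester with a straight chain shows that this aromatic carbon accepts (propylcarbonyl)oxy, with its 6 heavy atoms, in place of a single fluoro atom, with a 1.0-fold higher number from compound 3 to compound 4 (0.02 log units; within the scatter), or in place of hydrogen, with a 1.2-fold higher number from compound 2 to compound 4 (0.06 log units; within the scatter). Within the ester, propyl in place of isopropyl on the carbonyl carbon gives a 1.1-fold lower number from compound 1 to compound 4 (0.04 log units; within the scatter), so this change also stays within the scatter. Nothing measured here gives a reason for these small steps. As far as these compounds go, whether an amine or a carboxylic acid at this position, or a longer chain on the carbonyl carbon, would move the number beyond the scatter remains open.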